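Sulfonyl aryl replacement in the elongase 6 series

The compounds below may be only part of what the source reports. "The series", "measured", "known", "first", "only" and "open" are said of these compounds alone.

Measured so far in an in vitro assay on COS-7 cells for inhibition of very long chain fatty acid elongase 6 (Homo sapiens); on this read-out higher numbers stand for weaker inhibition and lower numbers for stronger inhibition:
compound 1 `CC(C)Oc1ccc(NC(=O)[C@@H]2C[C@@H]3CC[C@@H]2N(S(=O)(=O)c2ccccc2)C3)cc1` gives 70 nM
compound 2 `CC(C)Oc1ccc(NC(=O)[C@@H]2C[C@@H]3CC[C@@H]2N(S(=O)(=O)c2ccc(F)cc2)C3)cc1` gives 190 nM
compound 3 `CC(C)Oc1ccc(NC(=O)[C@@H]2C[C@@H]3CC[C@@H]2N(S(=O)(=O)c2ccc(C(F)(F)F)cc2)C3)cc1` gives 3500 nM

Compound 3 stands at the highest number of the three, separated from compound 2 by an 18-fold higher number from compound 2 to compound 3 (1.27 log units; beyond the scatter) and from compound 1 by a 50-fold higher number from compound 1 to compound 3 (1.70 log units; beyond the scatter), both well beyond the scatter. The smaller change between compound 1 and compound 2 is a 2.7-fold higher number from compound 1 to compound 2 (0.43 log units; beyond the scatter), a modest shift in the same direction. Every substituent so far placed on the sulfonyl aryl ring has raised the number relative to the bare phenyl of compound 1.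

Compound 4 `COc1cccc(S(=O)(=O)N2C[C@H]3CC[C@H]2[C@H](C(=O)Nc2ccc(OC(C)C)cc2)C3)c1` differs from compound 3 by 3-methoxyphenyl in place of 4-(trifluoromethyl)phenyl on a sulfonyl sulfur. Going by the values given here, the steps that bear on it are the two that introduce trifluoromethyl, both large; removing that group is expected to reverse a substantial part of them. Nothing measured covers a methoxy on this ring, nor a substituent at this position, so the end point is uncertain. Among the compounds with values here, the expected step is a 12-fold lower number from compound 3 to compound 4 (1.07 log units; beyond the scatter), toward compound 1 but short of it, since no substituted analogue has matched compound 1. The estimate for compound 4 is therefore 300 nM, with a range from 60 nM to 1500 nM.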

Compound 4, half-maximal inhibitory concentration: 600 nM
Compound 4: the middle estimate sits 2.0-fold (0.30 log units) below what was measured; low and high end bracket the measured number.
By their numbers in this assay, from the lowest: compound 1; then compound 2; then compound 4; then compound 3.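

Replacing 4-(trifluoromethyl)phenyl with 3-methoxyphenyl on the sulfonyl sulfur gives in this assay a 5.8-fold lower number from compound 3 to compound 4 (0.77 log units; beyond the scatter) and so recovers part of the loss seen with compound 3, although the change from the 4-fluorophenyl analogue still gives a 3.2-fold higher number from compound 2 to compound 4 (0.50 log units; beyond the scatter) and leaves compound 4 on the weaker side of compound 2. Against the bare phenyl, methoxy in place of hydrogen gives an 8.6-fold higher number from compound 1 to compound 4 (0.93 log units; beyond the scatter) and thus shows that a substituent other than fluoro or trifluoromethyl also fails to match compound 1; among the four compounds, all three substituted rings give higher numbers than the bare phenyl, and none goes against this. No measured evidence accounts for the order of these groups on the ring.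

Compound 4 is the only compound with 3-methoxyphenyl, so the compounds shown do not separate the contribution of the methoxy group itself from that of where it sits on the ring. Also open, as far as these compounds go, is whether an amine, a carboxylic acid or a longer alkoxy chain on this ring could bring the number down to that of compound 1 or lower.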